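The source may report more compounds than this note shows. Statements on the series, on what has been measured and on what is new or still open speak of the compounds shown alone.

In a functional assay on HCT-116 cells (Homo sapiens) for inhibition, read by resazurin assay, with a stated time of 5 days (a higher number here means a weaker inhibitor of growth, a lower number a stronger inhibitor of growth), compound 1 (`Cc1ccccc1S(=O)(=O)N1CCC(CCCC(=O)NO)CC1`) gives "not determined" (no result reported) and so offers no comparison. Compound 2 (`O=C(CCCC1CCN(S(=O)(=O)c2ccccc2Cl)CC1)NO`) gives 2800 nM as the only number shown, so it cannot yet be ranked against anything. Compound 3 (`O=C(CCCC1CCN(S(=O)(=O)Cc2ccccc2)CC1)NO`) carries benzyl in place of 2-chlorophenyl on a sulfonyl sulfur. Among the measured compounds shown here, no measured step exists to size this change, so in this assay nothing beyond the usual scatter is expected, in either direction. The estimated step (a 1.1-fold lower number from compound 2 to compound 3 (0.05 log units; within the scatter)) is expected to stay small. Compound 3 is expected at 2500 nM (estimated range 900 nM to 7000 nM).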

Compound 3, concentration for 50% growth inhibition: 3200 nM
Beside the measured number, compound 3's estimate is 1.3-fold (0.11 log units) below it; the measured number falls inside the stated range.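

Among the compounds shown here, the first sized change at this position, benzyl in place of 2-chlorophenyl on a sulfonyl sulfur, is a 1.1-fold higher number from compound 2 to compound 3 (0.06 log units; within the scatter) in this assay. Compound 2 and compound 3 therefore cannot be told apart in this assay, so moving from the aryl group to the benzyl group, with the same count of heavy atoms, does not separate them. No available evidence accounts for this result. From the compounds shown here alone, whether an amine or a carboxylic acid on the sulfonyl sulfur would separate from compound 2 stays open, as does the outcome of a longer chain in the shared core.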